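Swapping the amine on a chlorobenzamide vasopressin ligand

The source may report more compounds than this note shows. Statements on the series, on what has been measured and on what is new or still open speak of the compounds shown alone.

Measured so far in an assay on HeLa cells for binding affinity to Vasopressin V2 receptor (Homo sapiens); on this read-out higher numbers stand for weaker inhibition and lower numbers for stronger inhibition:
compound 1 `CN(C)c1ccc(C(=O)N2CCCCc3ccccc32)c(Cl)c1`: 18 nM
compound 2 `CN(C)c1ccc(C(=O)N2CCCCc3cc(Cl)ccc32)c(Cl)c1`: 13 nM
compound 3 `O=C(c1ccc(-n2cccc2)cc1)N1CCCCc2ccccc21`: 320 nM

Compound 2 gives the lowest of the three numbers. Its closest neighbour is compound 1, and the change a 1.4-fold lower number from compound 1 to compound 2 (0.14 log units; within the scatter) lies within the scatter, so the two are not distinguishable. Compound 3, which carries a different group on the benzamide ring and lacks the chloro on the other ring, sits far higher.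

Compound 4 `O=C(c1ccc(N2CCCC2)cc1Cl)N1CCCCc2cc(Cl)ccc21` differs from compound 2 by pyrrolidin-1-yl in place of dimethylamino on an aromatic carbon. Among the measured compounds shown here, none of the measured steps touches this group, so no step bears directly on the change. The nearest comparison is the general closeness of compounds 1 and 2. The expectation is therefore a step of a 1.2-fold higher number from compound 2 to compound 4 (0.06 log units; within the scatter) that stays within the scatter in this assay. Compound 4 is estimated at 15 nM, between 5 nM and 45 nM.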

Compound 4, half-maximal inhibitory concentration: 16 nM
Compound 4: the middle estimate sits 1.1-fold (0.03 log units) below what was measured; low and high end bracket the measured number.
By their numbers in this assay, from the lowest: compounds 2, 4 and 1 (each within the scatter of the next); then compound 3.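

Swapping the group on this aromatic carbon, para to a large group, gives a 1.2-fold higher number from compound 2 to compound 4 (0.09 log units; within the scatter) in this assay. Pyrrolidin-1-yl, with 5 heavy atoms and a five-membered non-aromatic ring, therefore cannot be told apart here from dimethylamino, with 3 heavy atoms and no ring, so this position accepts the ring and the extra atoms without a detectable penalty. No evidence is available to explain this result.

Still open, on these data alone, is whether the same holds for a piperidine ring or a carboxylic acid at this aromatic carbon. A primary amine there is equally untested by these compounds.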